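The compounds below may be only part of what the source reports. "The series", "measured", "known", "first", "only" and "open" are said of these compounds alone.

Measured compounds in an assay on HEK293 cells for binding affinity to prostaglandin E2 receptor EP2 subtype (Homo sapiens); a lower number here means a stronger inhibitor, a higher number a weaker inhibitor:

compound 1 `O=C(O)CCc1ccccc1-c1cccc(-c2ccccc2OCc2ccccc2)c1`, 3700 nM
compound 2 `O=C(O)CCCc1ccccc1-c1cccc(-c2ccccc2OCc2ccccc2)c1`, 3500 nM
compound 3 `O=C(O)CCc1ccccc1-c1cc(-c2ccccc2OCc2ccccc2)cs1`, 2900 nM

Compound 2 gives the second highest of the three numbers in this assay; compound 1 and compound 3 both lie within the scatter of it, so none of the three can be ranked against the others.

Compound 4 `CC(Cc1ccccc1-c1cccc(-c2ccccc2OCc2ccccc2)c1)C(=O)O` is not yet measured. It differs from compound 2 by 1-carboxyethyl in place of 2-carboxyethyl on a saturated chain carbon bound to an aromatic carbon. The acid is kept, the chain is rearranged rather than lengthened or shortened.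

For the measured compounds named here, the one measured step that touches this part of the molecule is a 1.1-fold lower number from compound 1 to compound 2 (0.02 log units; within the scatter). Moving the acid one carbon further out changed nothing beyond the scatter, so the acid position in this region appears tolerant to small changes on the numbers so far. Going by the values given here, only one such step exists, and none tests a branched chain, so the expectation is uncertain.

The step from compound 2 to compound 4 in this assay is therefore expected to be no change at the digits printed from compound 2 to compound 4 (within the scatter), not beyond the scatter. Compound 4 is estimated at 3500 nM, with a range from 1500 nM to 8500 nM.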

Compound 4, inhibition constant: 3600 nM
Compound 4: the middle estimate sits 1.0-fold (0.01 log units) below what was measured, and the stated range covers the measured number.
By their numbers in this assay, from the lowest: compounds 3, 2, 4 and 1 (each within the scatter of the next).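

In this assay, the first branched chain in the series gives a 1.0-fold higher number from compound 2 to compound 4 (0.01 log units; within the scatter), so the two arrangements of the acid chain cannot be told apart. Read the other way, as methyl in place of hydrogen on a saturated chain carbon bound to a carbonyl carbon and a saturated chain carbon, compound 4 shows a 1.0-fold lower number from compound 1 to compound 4 (0.01 log units; within the scatter), so a methyl branch at this carbon also has no effect that can be separated from the scatter. No supporting data bear on why this chain tolerates the rearrangement and the branch.

The compounds shown leave open whether any change at this chain can move the number beyond the scatter. An ethyl or a second methyl on the same carbon would probe that limit, and a primary amide or tetrazole in place of the carboxylic acid would test whether the acid itself is needed.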